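Working notes on cytotoxicity across a small series

A few compounds are considered here, and "the series" means these few. Any claim that something is new, unique, unknown or untested is made for them only; others in the source may bear on it.

The series is followed in an ADME assay on L929 cells (Mus musculus) for cytotoxicity, read by resazurin assay, with a stated time of 72 h; on this read-out lower numbers stand for stronger inhibition and higher numbers for weaker inhibition. Compound 1 `CNC(=O)c1cccn1-c1ccc2c(c1)B(O)OC2` carries the shared core with a methyl amide on the five-membered ring. In this assay compound 1 gives > 10 ug/mL, a limit of the assay and not a number. Compound 2 `CCc1ccc(C(=O)c2ccn(-c3ccc4c(c3)B(O)OC4)c2)cc1` bears a ketone on the five-membered ring instead. In this assay compound 2 gives > 10 ug/mL, again a limit of the assay and not a number. Compound 2 therefore stands where every value of the series stands so far, since (the limit of > 10 ug/mL in this assay, at which 2 of the 2 values shown sit), and no numbered comparison between the two compounds is possible.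

Compound 3 `Cc1ccc(C(=O)c2ccn(-c3ccc4c(c3)B(O)OC4)c2)s1` is not yet measured. It differs from compound 2 in one place: 5-methylthiophen-2-yl in place of 4-ethylphenyl on a carbonyl carbon. No measured step between two compounds of this series is available to size the effect of such a change, so the expectation rests only on the two limits shown. The step from compound 2 to compound 3 in this assay is expected to be none beyond the scatter, a step that the limit leaves unreadable from compound 2 to compound 3. Compound 3 is estimated at 20 ug/mL, within a range of 8 ug/mL to 60 ug/mL, most likely reported again as a limit.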

Compound 3, half-maximal inhibitory concentration: > 10 ug/mL
Compound 3 gave a limit, no number; the forecaster's own chance of this, stated with the estimate: 80%; the middle value does not contradict the limit.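

In this assay compound 3 gives > 10 ug/mL, a limit of the assay and not a number. Among the compounds shown here, no step between compound 2 and compound 3 can be read, and the series still sits at a single limit: the limit of > 10 ug/mL in this assay, at which 3 of the 3 values shown sit. The compounds shown leave open whether any change on the shared core would give a number rather than a limit in this assay.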